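Replacing the methyl group of compound 1

This account rests on a few compounds, and the source may have more. Where it says the series, first, only, none or still open, it means among the compounds named here.

In a functional assay on HeLa cells (Homo sapiens) for inhibition, read by CCK-8 assay, with a stated time of 48 h (a lower number here means a stronger inhibitor, a higher number a weaker inhibitor), compound 1 (`COc1cc(-c2ccnc3cc(-c4ccc(C)cc4)nn23)cc(OC)c1OC`) gives 21 nM and compound 2 (`COc1cc(-c2ccnc3cc(-c4ccc5c(ccn5C)c4)nn23)cc(OC)c1OC`) gives 19 nM, so the two lie within the scatter of each other, with a 1.1-fold lower number from compound 1 to compound 2 (0.04 log units; within the scatter) between them. Both sit far under compound 3 (`COc1cc(-c2ccnc3cc(-c4cn(C)c5ccccc45)nn23)cc(OC)c1OC`) at 399 nM, with a 19-fold higher number from compound 1 to compound 3 (1.28 log units; beyond the scatter) and a 21-fold higher number from compound 2 to compound 3 (1.32 log units; beyond the scatter) marking large gaps. Compound 4 (`COc1cc(-c2ccnc3cc(-c4ccc(-c5cnn(C)c5)cc4)nn23)cc(OC)c1OC`) carries 1-methyl-1H-pyrazol-4-yl in place of methyl on an aromatic carbon. Within the data shown here, no measured step makes this exact change. The swaps of the whole group at this place were either silent or large, so a moderate rise in this assay is expected, amounting to a 1.9-fold higher number from compound 1 to compound 4 (0.28 log units; within the scatter) overall. For compound 4 the estimated value is 40 nM, within a range from 12 nM to 150 nM as expected here.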

Compound 4, half-maximal inhibitory concentration: 1830 nM
Estimate against measurement, compound 4: 46-fold (1.66 log units) below; the measured number lies above the stated range.
By their numbers in this assay, from the lowest: compounds 2 and 1 (each within the scatter of the next); then compound 3; then compound 4.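

Replacing methyl with 1-methyl-1H-pyrazol-4-yl gives an 87-fold higher number from compound 1 to compound 4 (1.94 log units; beyond the scatter) in this assay. The earlier compounds shown here exchanged the whole group on the shared core, whereas this step shows that a change confined to the methyl place, on the six-membered aromatic ring of carbon only, can by itself weaken inhibition sharply. Nothing available explains this rise. As far as these compounds go, it remains open whether a smaller group at this place, such as an amine, a methoxy or a hydroxyl, would stay close to compound 1, or whether a phenyl ring would behave like the pyrazole.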